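The source may hold more compounds than are shown below. What is called first, only, known or untested is meant among the compounds shown, and "the series" means these compounds.

Measured compounds: compound 1 `c1coc(-c2ccccc2NCC2=NCCN2)c1`, compound 2 `Cc1cc(-c2ccccc2NCC2=NCCN2)on1`, compound 3 `Cc1noc(-c2ccccc2NCC2=NCCN2)n1`.

In a functional assay for activation of Alpha-1D adrenergic receptor (Homo sapiens) (on this read-out higher numbers stand for an effect only at larger amounts of compound and lower numbers for an effect already at smaller amounts), compound 1 gives 16.2 nM. Compound 2 gives only a limit in this assay, < 100000 nM. Compound 3 likewise gives only a limit, < 5020 nM. Compound 2 thus stands at the limit of < 100000 nM in this assay, at which 1 of the 3 values shown sits, and its place relative to the other two cannot be read: a step that the limit leaves unreadable from compound 1 to compound 2, a step that the two limits leave unreadable from compound 2 to compound 3, and also a step that the limit leaves unreadable from compound 1 to compound 3 with compound 3 at the limit of < 5020 nM in this assay, at which 1 of the 3 values shown sits.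

The change to compound 4 `Cc1ccc(-c2ccccc2NCC2=NCCN2)o1` is 5-methylfuran-2-yl in place of 3-methyl-1,2-oxazol-5-yl on an aromatic carbon. Going by the values given here, no measured step of readable size bears on it. The nearest anchor is compound 1, a furan on the same core, with 16.2 nM; compound 4 carries a methyl on that ring. Compound 4 is expected to fall in that region: 50 nM (range 8 nM to 400 nM). The expected step that the limit leaves unreadable from compound 2 to compound 4 remains unreadable against a limit.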

Compound 4, half-maximal effective concentration: < 2000 nM
Compound 4 gave a limit, no number; the forecaster's own chance of this, stated with the estimate: 10%; the middle value lies beyond the limit too.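

Compound 4 gives only a limit, so its steps from compound 1, compound 2 and compound 3 cannot be read in this assay. Still open, from the compounds shown here alone, is how the methyl on the furan ring of compound 4 shifts the read-out relative to compound 1.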